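Replacing a Boc-azetidine Amide with an Isopropyl(methyl)amide

The source may hold more compounds than are shown below. What is called first, only, known or untested is meant among the compounds shown, and "the series" means these compounds.

Compound 1 `CCN(CC)S(=O)(=O)c1ccc(S(=O)(=O)N2CCC[C@@H](C(=O)NC3CN(C(=O)OC(C)(C)C)C3)C2)cc1`: 100 nM
Compound 2 `CCOC(=O)[C@@H]1CCC[C@H](S(=O)(=O)c2ccc(S(=O)(=O)N(CC)CC)cc2)C1`: > 10000 nM
Compound 3 `CCOC(=O)N1CCC[C@H](S(=O)(=O)c2ccc(S(=O)(=O)N(CC)CC)cc2)C1`: > 10000 nM

The three measured compounds were tested in a functional assay on MIA PaCa-2 cells (Homo sapiens) for inhibition, read by MTT assay, with a stated time of 3 days; on this read-out higher numbers stand for weaker inhibition and lower numbers for stronger inhibition. For the measured compounds named here, compound 1 gives 100 nM, the only numerical value among them. Compound 2 reaches only (the limit of > 10000 nM in this assay, at which 2 of the 3 values shown sit), which is a limit of the assay rather than a number. Compound 3 likewise sits at that limit, with > 10000 nM. Going by the values given here, compounds 2 and 3 differ from compound 1 in more than one place, so no step between measured compounds can be drawn, and their limits say only that they are weaker than compound 1.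

Compound 4 `CCN(CC)S(=O)(=O)c1ccc(S(=O)(=O)N2CCC[C@@H](C(=O)N(C)C(C)C)C2)cc1` keeps the shared core of compound 1 and changes the amide substituent: isopropyl(methyl)amino in place of (1-(tert-butoxycarbonyl)azetidin-3-yl)amino on a carbonyl carbon. Among the compounds with values here, no measured pair bears on this change, so the expected size of the step rests on the structure alone. Compound 4 is expected to give 500 nM, within 100 nM to 5000 nM. The step from compound 1 to compound 4 is estimated at a 5.0-fold higher number from compound 1 to compound 4 (0.70 log units; beyond the scatter), a moderate loss, with a fair chance the assay reports only a limit.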

Compound 4, half-maximal inhibitory concentration: 1400 nM
Compound 4: the middle estimate sits 2.8-fold (0.45 log units) below what was measured; low and high end bracket the measured number.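

In this assay, for the compounds shown here, the amide substituent on the carbonyl carbon proves to matter, giving the first readable step in the set: a 14-fold higher number from compound 1 to compound 4 (1.15 log units; beyond the scatter). This large loss shows that isopropyl(methyl)amino does not replace (1-(tert-butoxycarbonyl)azetidin-3-yl)amino on the shared core without cost, although several features change at once: the four-membered ring, the hydrogen-bond donor, the hydrogen-bond acceptors and much of the heavy-atom count all leave together, so the step cannot be assigned to any one of them. Compound 4 nevertheless gives a number and not a limit, so the read-out remains measurable without the four-membered ring: the limit of > 10000 nM in this assay, at which 2 of the 4 values shown sit.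

The compounds shown leave open which part of the departing group accounts for the difference, for instance whether a plain isopropylamino group, which would restore the amide hydrogen without the ring, would recover the lost strength. They also leave open whether the tert-butoxycarbonyl group is needed at all, a question that the free azetidine secondary amine or a simple acetyl group on the same ring nitrogen would address.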